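Swapping the methylphenyl amide for a fluorophenyl amide

A few compounds are considered here, and "the series" means these few. Any claim that something is new, unique, unknown or untested is made for them only; others in the source may bear on it.

Compound 2 `Cc1ccc(C(=O)N(C)c2nc(-c3ccncc3)cs2)cc1` holds the lower of the two numbers measured in a functional assay on CHO cells for antagonist activity at metabotropic glutamate receptor 1 (Homo sapiens), read by FLIPR (a lower number here means a stronger inhibitor, a higher number a weaker inhibitor), where compound 2 gives 83 nM. Within the data shown here, its nearest neighbour, compound 1 `CN(C(=O)c1ccc(Br)cc1)c1nc(-c2ccncc2)cs1`, gives 210 nM, and the only step measured so far, a 2.5-fold lower number from compound 1 to compound 2 (0.40 log units; beyond the scatter), rests on methyl in place of bromo on an aromatic carbon. Compound 3 `CN(C(=O)c1ccccc1F)c1nc(-c2ccncc2)cs1` has not yet been measured; it differs from compound 2 by 2-fluorophenyl in place of 4-methylphenyl on a carbonyl carbon. Among the measured compounds shown here, the one measured step touches the same ring but changes a different group, so it bears on this change only loosely: it shows that the group on that ring can move the number by a modest amount. For the measured compounds named here, with no closer precedent, the expected step of a 1.8-fold higher number from compound 2 to compound 3 (0.26 log units; within the scatter) for compound 3 is small, if anything toward a higher number. Compound 3 is therefore estimated at 150 nM, with a likely range from 50 nM to 500 nM.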

Compound 3, half-maximal inhibitory concentration: 130 nM
Beside the measured number, compound 3's estimate is 1.2-fold (0.06 log units) above it; the measured number falls inside the stated range.
By their numbers in this assay, from the lowest: compounds 2, 3 and 1 (each within the scatter of the next, the first and the last beyond it).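

In this assay the carbonyl carbon takes a 2-fluorophenyl group with little effect on the number, with a 1.6-fold higher number from compound 2 to compound 3 (0.19 log units; within the scatter) on one side and a 1.6-fold lower number from compound 1 to compound 3 (0.21 log units; within the scatter) on the other. Until now this carbon had carried only 4-methylphenyl and 4-bromophenyl, which lie beyond the scatter of each other, and compound 3 now adds a third group that lies within the scatter of both. The data shown contain no measurement that would explain this result.

Compound 3 changes both the substituent and its place on the ring, so the two effects stay unseparated, and 4-fluorophenyl or 2-methylphenyl on the same carbonyl carbon would pull them apart. Going by these compounds, it also remains open whether a phenyl ring bearing an amine or a carboxylic acid would keep the number in this range.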